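The source may report more compounds than this note shows. Statements on the series, on what has been measured and on what is new or still open speak of the compounds shown alone.

In a functional assay on A549 cells (Homo sapiens) for cytotoxicity, read by XTT assay, with a stated time of 72 h (on this read-out higher numbers stand for weaker inhibition and lower numbers for stronger inhibition), compound 3 `O=C1C=CC(=O)C(c2cc(-c3ccc(C(=O)N4CCCCC4)s3)on2)=C1` gives only a limit, > 30000 nM. Compound 1 `CN(C)C(=O)c1ccc(-c2cc(C3=CC(=O)C=CC3=O)no2)s1` likewise stops at a limit in this assay, > 30000 nM. Compound 2 `O=C1C=CC(=O)C(c2cc(-c3ccc(C(=O)N4CCC(C(F)(F)F)CC4)s3)on2)=C1` also stops at a limit, > 30000 nM. With all three values sitting at the ceiling, the limit of > 30000 nM in this assay, at which 3 of the 3 values shown sit, is the whole of what the measured set shows, and the steps a step that the two limits leave unreadable from compound 1 to compound 3, a step that the two limits leave unreadable from compound 1 to compound 2 and a step that the two limits leave unreadable from compound 2 to compound 3 remain unreadable: none of the variations of the amine on the carbonyl carbon, from dimethylamino through piperidin-1-yl to 4-(trifluoromethyl)piperidin-1-yl, has been resolved below the limit.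

Compound 4 `CN(Cc1ccc(F)cc1)C(=O)c1ccc(-c2cc(C3=CC(=O)C=CC3=O)no2)s1` differs from compound 3 by (4-fluorobenzyl)(methyl)amino in place of piperidin-1-yl on a carbonyl carbon. Among the compounds with values here, no measured step bears readably on this change, since every comparison among the measured compounds is bounded by the same limit. Compound 4 is therefore expected to stay at the limit as well, the expected step being a number no higher from compound 3 to compound 4 (the limit leaves the size open). The estimate for compound 4 in this assay is 30000 nM, with a range from 10000 nM to 100000 nM, and most likely only a limit will be reported.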

Compound 4, half-maximal inhibitory concentration: > 30000 nM
Compound 4: no number, only a limit; the forecaster's own chance of this, stated with the estimate: 80%; the middle value sits exactly at the limit.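

In this assay compound 4 gives > 30000 nM, a limit and not a number. Within the data shown here, no new step to compound 4 can be read from compound 1, compound 2 or compound 3: the limit of > 30000 nM in this assay, at which 4 of the 4 values shown sit. The compounds shown leave open whether any group on this carbonyl carbon gives a measurable value.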